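Adding Fluoro to the Phenylsulfonyl Group of Compound 2

This account rests on a few compounds, and the source may have more. Where it says the series, first, only, none or still open, it means among the compounds named here.

In a functional assay on SMMC-7721 cells (Homo sapiens) for cytotoxicity, read by MTT assay, with a stated time of 24 h (a lower number here means a stronger inhibitor, a higher number a weaker inhibitor), compound 1 (`O=C1/C(=C/c2ccncc2)CNC/C1=C\c1ccccc1C(F)(F)F`) gives 4500 nM and compound 2 (`O=C1/C(=C/c2ccncc2)CN(S(=O)(=O)c2ccccc2)C/C1=C\c1ccccc1C(F)(F)F`) gives 6540 nM, so these two values lie within the usual scatter of each other. Compound 3 (`O=C1/C(=C/c2ccncc2)CN(S(=O)(=O)c2ccc(F)cc2)C/C1=C\c1ccccc1C(F)(F)F`) has fluoro in place of hydrogen on an aromatic carbon of compound 2: fluoro in place of hydrogen on an aromatic carbon. Going by the values given here, the only measured step is a different change, phenylsulfonyl in place of hydrogen, and it gave a 1.5-fold higher number from compound 1 to compound 2 (0.16 log units; within the scatter). Among the compounds with values here, no measured step tests fluoro, so no shift beyond the scatter is expected. The estimated step is a 1.1-fold lower number from compound 2 to compound 3 (0.04 log units; within the scatter). Compound 3 is expected at 6000 nM, with an estimated range of 2800 nM to 13000 nM.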

Compound 3, half-maximal inhibitory concentration: 9270 nM
Compound 3: the middle estimate sits 1.5-fold (0.19 log units) below what was measured; the measured number falls inside the stated range.
By their numbers in this assay, from the lowest: compounds 1, 2 and 3 (each within the scatter of the next, the first and the last beyond it).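

Fluoro on an aromatic carbon of the phenylsulfonyl group gives a 1.4-fold higher number from compound 2 to compound 3 (0.15 log units; within the scatter) in this assay, so this single change cannot be told apart from the scatter. Measured against hydrogen on the ring amine nitrogen, however, the whole (4-fluorophenyl)sulfonyl group gives a 2.1-fold higher number from compound 1 to compound 3 (0.31 log units; beyond the scatter), a modest step beyond the scatter, whereas phenylsulfonyl alone stayed within it. No evidence at hand explains either step. Going by these compounds, whether chloro or a methoxy group in the same place would move the number further remains open, as does the effect of fluoro on another carbon of that ring.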